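Moving the fluorine around the sulfonyl-linked phenyl ring

The source may hold more compounds than are shown below. What is called first, only, known or untested is meant among the compounds shown, and "the series" means these compounds.

The pair measured so far shares one core and differs only in the ring attached to the sulfonyl sulfur. Compound 1 `O=C(NCc1ccc(CNS(=O)(=O)c2ccccc2Cl)cc1)c1cccnc1` carries a 2-chlorophenyl there, and in an assay on MDA-MB-231 cells for displacement of a labelled ligand from C-X-C chemokine receptor type 4 (Homo sapiens), read by fluorescence and microscopy, with stated times of 10 min and 30 min (a lower number here means that less compound is needed, a higher number that more compound is needed for the effect), compound 1 gives 100 nM. Compound 2 `O=C(NCc1ccc(CNS(=O)(=O)c2cccc(F)c2)cc1)c1cccnc1` carries a 3-fluorophenyl instead, and in this assay compound 2 gives 1000 nM. That single change is recorded as a 10-fold higher number from compound 1 to compound 2 (1.00 log units; beyond the scatter), so compound 2 stands with the highest of the two numbers, with compound 1 the nearest neighbour at the lower end.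

Compound 3 `O=C(NCc1ccc(CNS(=O)(=O)c2ccccc2F)cc1)c1cccnc1` has not yet been measured. Its difference from compound 2 is 2-fluorophenyl in place of 3-fluorophenyl on a sulfonyl sulfur. Going by the values given here, the one measured step bears on it only in part, since from compound 1 to compound 2 the halogen and its ring position changed together. Compound 3 keeps the fluorine of compound 2 but places it as in the 2-chlorophenyl of compound 1, so a lower number than compound 2 is expected, but not the full return to compound 1. Compound 3 is estimated at 300 nM, within 100 nM to 1000 nM, a step of a 3.3-fold lower number from compound 2 to compound 3 (0.52 log units; beyond the scatter).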

Compound 3, effective concentration (reported as EC, without a stated level of effect): 100 nM
Beside the measured number, compound 3's estimate is 3.0-fold (0.48 log units) above it, and the stated range covers the measured number.
By their numbers in this assay, from the lowest: compounds 1 and 3 (each within the scatter of the next); then compound 2.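

With the atoms unchanged and only the fluorine moved, this assay records a 10-fold lower number from compound 2 to compound 3 (1.00 log units; beyond the scatter), so the ring position of the halogen on the phenyl attached to the sulfonyl sulfur matters by itself, which the first pair could not show, as halogen and position changed together there. The second new comparison keeps that placement and exchanges the halogen, and it gives no change at the digits printed from compound 1 to compound 3 (within the scatter), so at this placement the 2-fluorophenyl and the 2-chlorophenyl are not told apart in these numbers, and the gap in the first pair can be read as matching the change of position rather than of halogen. Nothing measured here accounts for why the position of the halogen counts.

Still open is whether the same gap would appear with chlorine, placed as the fluorine stands in the 3-fluorophenyl, since only fluorine has been seen at that position among these compounds. The compounds shown also leave open what a phenyl with no halogen at all, or one carrying a methoxy or nitrile group in place of the halogen, would give on the same core.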